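This account rests on a few compounds, and the source may have more. Where it says the series, first, only, none or still open, it means among the compounds named here.

Three compounds have been measured in an in vitro functional assay on HEK285-7 cells for antagonist activity at prostaglandin D2 receptor 2 (Homo sapiens), read by BRET and beta-arrestin recruitment; a higher number here means a larger maximal response, a lower number a smaller maximal response:

Compound 1 `COc1cc(-c2nc(C(c3ccc(F)cc3)c3ccc(F)cc3)sc2CC(=O)O)ccn1` gives 60%.
Compound 2 `Cc1nc(-c2ccc(Cl)cc2)c(CC(=O)O)s1` gives 50%.
Compound 3 `O=C(O)Cc1sc(C(c2ccccc2)c2ccccn2)nc1-c1ccc(Cl)cc1` gives 55%.

All three share the same core carrying a carboxymethyl group, and differ in the groups attached to it. Among the three numbers, the value of compound 1 is the highest, but its gap to compound 3 and its gap to compound 2 both fall within the usual scatter of this assay, so the three cannot be told apart on these data.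

Compound 4 `Cc1cc(-c2nc(C(c3ccc(F)cc3)c3ccc(F)cc3)sc2CC(=O)O)cnc1N` is not yet measured. It differs from compound 1 in one place: 6-amino-5-methylpyridin-3-yl in place of 2-methoxypyridin-4-yl on an aromatic carbon. Among the measured compounds shown here, no pair of measured compounds shows what such an exchange does, so there is no step to lean on.

With three values that all lie within the scatter of one another, the most reasonable expectation is that the exchange in this assay changes little, and the step from compound 1 to compound 4 is estimated at no change at the digits printed from compound 1 to compound 4 (within the scatter), which is no step beyond the scatter. Compound 4 is therefore expected to give about 60%, between 45% and 75%.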

Compound 4, largest response reached (reported as efficacy), in percent of the reference or control that the assay uses: 80%
Beside the measured number, compound 4's estimate is 20 percentage points below it; the whole stated range lies below it.
By their numbers in this assay, from the lowest: compounds 2, 3 and 1 (each within the scatter of the next); then compound 4.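

In this assay, the group on this aromatic carbon, next to the ring nitrogen, clearly counts: putting 6-amino-5-methylpyridin-3-yl in place of 2-methoxypyridin-4-yl gives a number 20 percentage points higher from compound 1 to compound 4 (beyond the scatter). The two groups match in heavy-atom count and each has a six-membered aromatic ring with one hetero atom, yet only the entering group has a hydrogen-bond donor, so a change that leaves the size of the group the same can still move this number. Nothing available explains the step.

The exchange alters several features at once, so the amine, the methyl, the loss of the methoxy group and the new ring attachment point cannot be separated. A comparison with 6-aminopyridin-3-yl or 5-methylpyridin-3-yl at this place would show which features carry the step.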